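The compounds below may be only part of what the source reports. "The series", "measured", "known", "first", "only" and "open" are said of these compounds alone.

Compound 1, `c1ccc(C(/N=C2\CCCCCCN2)C2CC2)cc1`, gives 0% in a functional assay on the whole organism (plasma, strain Sprague-Dawley) with Rattus norvegicus as the target, with a stated time of 2 h, at a dose of 12.5 mg/kg by the oral route; a higher number here means a stronger effect of the compound at the dose given, a lower number a weaker effect.
Compound 2, `c1csc(C(/N=C2\CCCCCCN2)C2CC2)c1`, gives 17% in this assay.

Compound 1 stands lowest of the two numbers shown; its nearest neighbour is compound 2, reached by a number 17 percentage points higher from compound 1 to compound 2 (beyond the scatter), a modest rise. Compound 3, `c1ccc(C(/N=C2\CCCCCCN2)c2ccco2)cc1`, differs from compound 1 by furan-2-yl in place of cyclopropyl on a saturated chain carbon bound to an aromatic carbon and a double-bonded nitrogen. For the measured compounds named here, no measured step exchanges the cyclopropyl; the only step known, from compound 1 to compound 2, swaps phenyl for thiophen-2-yl at a different group and so bears on the new change only loosely. That step shows that putting in a five-membered aromatic ring with one hetero atom raised the number modestly. On that thin ground a small step upward is expected in this assay, a number 10 percentage points higher from compound 1 to compound 3 (within the scatter), though a step within the scatter would not surprise. The estimate for compound 3 is 10%, with a range from 0% to 30%.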

Compound 3, a percentage reported as inhibition, in the whole organism at one dose (the size of the read-out at that dose, not a potency): 22%
The estimate for compound 3 lay 12 percentage points below the measured number; low and high end bracket the measured number.
By their numbers in this assay, from the lowest: compound 1; then compounds 2 and 3 (each within the scatter of the next).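

At the saturated chain carbon bound to an aromatic carbon and a double-bonded nitrogen, replacing the cyclopropyl of compound 1 with furan-2-yl gives a clear gain in this assay, a number 22 percentage points higher from compound 1 to compound 3 (beyond the scatter). This is the first shown change at this place, and it shows that an effect can be measured without the cyclopropyl. The change swaps a three-membered non-aromatic ring for a five-membered aromatic ring with 1 hetero atom and 1 hydrogen-bond acceptor, but no measurement at hand says which of these differences accounts for the gain.

On these data alone, it remains open whether the aromatic ring or its oxygen matters here, a question that a tetrahydrofuran ring or a pyridine ring at this place would address. For the compounds shown here, the read-out comes from a single dose, so it shows only that compound 3 has a stronger effect than compound 1 at that dose.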